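The compounds below may be only part of what the source reports. "The series", "measured", "known", "first", "only" and "open" are said of these compounds alone.

Working notes on the series. Going by the values given here, in a functional assay on MGC-803 cells (Homo sapiens) for antiproliferative activity, read by MTT assay, with a stated time of 72 h (on this read-out lower numbers stand for stronger inhibition and higher numbers for weaker inhibition), compound 1 `COc1ccc(-n2nc(-c3ccccc3)nc2CNc2ccc(C(=O)NO)cc2)cc1` gives 7050 nM and compound 2 `O=C(NO)c1ccc(NCc2nc(-c3ccccc3)nn2-c2ccc(Br)cc2)cc1` gives 9300 nM with the two values within the scatter of each other, so compound 2 stands level with compound 1 on the numbers so far. Compound 3 `O=C(NO)c1ccc(NCc2nc(-c3ccccc3)nn2-c2cccc(Cl)c2)cc1` carries 3-chlorophenyl in place of 4-bromophenyl on an aromatic nitrogen and is still to be measured. Among the compounds with values here, one measured step bears on this change: a 1.3-fold higher number from compound 1 to compound 2 (0.12 log units; within the scatter) for bromo in place of methoxy on an aromatic carbon. Within the data shown here, no measured compound carries a chloro group or a 3-chlorophenyl, so the evidence is thin. The estimated step of a 1.2-fold lower number from compound 2 to compound 3 (0.07 log units; within the scatter) is therefore expected to stay within the scatter in this assay with no clear direction. For compound 3 the expected value is 8000 nM with an estimated range of 3500 nM to 18000 nM for now.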

Compound 3, half-maximal inhibitory concentration: 13700 nM
Compound 3: the middle estimate sits 1.7-fold (0.23 log units) below what was measured; the measured number falls inside the stated range.
By their numbers in this assay, from the lowest: compounds 1, 2 and 3 (each within the scatter of the next).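

In this assay the change to 3-chlorophenyl on the aromatic nitrogen gives a 1.5-fold higher number from compound 2 to compound 3 (0.17 log units; within the scatter) and a 1.9-fold higher number from compound 1 to compound 3 (0.29 log units; within the scatter) and so all three compounds remain level on these numbers. The earlier step exchanged methoxy for bromo, whereas these steps also set a 3-chlorophenyl in place of a 4-substituted phenyl, and even this change to the group on the aromatic nitrogen does not separate the values. Nothing measured here offers an explanation for these values.

As far as these compounds go, whether this position would stay equally flat with a basic amine or a carboxylic acid on the phenyl ring remains open. The same holds for a longer alkyl chain in place of the phenyl ring, and for the plain phenyl group as the reference point for all three compounds.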